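Methoxy to hydroxy change in a weakly active trio

The source may report more compounds than this note shows. Statements on the series, on what has been measured and on what is new or still open speak of the compounds shown alone.

Compound 1 `COc1cc(C)cc(-c2c(-c3ccnc(-c4ccc(N(C)C)cc4)c3)cnn2CC#N)c1` in a functional assay on Malme-3M cells (Homo sapiens) for inhibition, read by sulforhodamine B assay, with a stated time of 48 h (on this read-out higher numbers stand for weaker inhibition of growth and lower numbers for stronger inhibition of growth), gives > 100000 nM, which is a limit of the assay and not a number.
Compound 2 `COc1cc(C)cc(-c2nn(CC#N)cc2-c2ccnc(-c3ccc(N(C)C)cc3)c2)c1` in this assay gives > 100000 nM, again a limit of the assay rather than a number.
Compound 3 `COc1cc(C)cc(-c2nn(CC#N)cc2-c2ccc(-c3cccc(C(C)=O)c3)nc2)c1` in this assay gives 96400 nM.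

Compound 2 therefore stands at the limit of > 100000 nM in this assay, at which 2 of the 3 values shown sit, and nothing sharper than that limit is known for it. Compound 3 is the only one of the three with a number, and that number sits close to the same limit. For the measured compounds named here, none of the three measured compounds differs from another in a single place, so no measured step within the set exists to lean on.

Compound 4 `Cc1cc(O)cc(-c2nn(CC#N)cc2-c2ccnc(-c3ccc(N(C)C)cc3)c2)c1` has not been measured in this assay. It differs from compound 2 by hydrogen in place of methyl on an oxygen on an aromatic ring. Going by the values given here, with compound 2 known only as a limit, and no measured step of comparable kind, the expected step from compound 2 to compound 4 is none beyond the scatter: a number no higher from compound 2 to compound 4 (the limit leaves the size open) is the working expectation. Compound 4 is accordingly estimated at 100000 nM, with a range from 30000 nM to 300000 nM, and with a considerable chance that this assay again reports only a limit for compound 4.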

Compound 4, concentration for total growth inhibition: 39200 nM
Beside the measured number, compound 4's estimate is 2.6-fold (0.41 log units) above it, within the range that was stated.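

Methoxy to hydroxy on the 3-methoxy-5-methylphenyl group gives an at least 2.5-fold lower number from compound 2 to compound 4 (0.40 log units; beyond the scatter) in this assay, the first measured step in the series between compounds that differ in one place. This shows that the group on this oxygen on an aromatic ring can matter to the read-out: with hydrogen in place of methyl, compound 4 gives a number, 39200 nM, and the direction is towards stronger inhibition of growth. As far as these compounds go, the step can be read only as a minimum, and its full size stays unknown, because the value for compound 2 is a limit of the assay and not a number: the limit of > 100000 nM in this assay, at which 2 of the 4 values shown sit.

Whether the same change carries over to the different cores of compound 1 and compound 3 remains open, since the compounds shown include no hydroxy counterpart of either. Also open, from the compounds shown here alone, is how far the read-out depends on the group at this place, for instance if an amine or a carboxylic acid stood in place of the hydroxy group, or if a longer chain stood on the oxygen in place of methyl.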